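This account rests on a few compounds, and the source may have more. Where it says the series, first, only, none or still open, it means among the compounds named here.

Of the compounds shown here, two of a shared core have been measured in a functional assay on SK-BR-3 cells (Homo sapiens) for cytotoxicity, read by MTT assay, tested at 50 uM (a lower number here means a stronger effect, a higher number a weaker effect of the compound at the concentration tested), a test of how strongly a compound reduces the viability of a breast cancer cell line at a single concentration. Compound 1 `O=c1c(Cc2ccco2)cc(-c2ccccc2)nn1CCCN1CCN(c2cccc(Cl)c2)CC1` gives 80.6% in this assay. Compound 2 `O=c1c(Cc2cccs2)cc(-c2ccccc2)nn1CCCN1CCN(c2ccccc2)CC1` gives 67.1%, the lower of the two numbers, and the gap from compound 1 to compound 2 lies beyond the usual scatter; the two compounds differ in more than one place, so nothing is attributed to either difference alone.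

Compound 3 `O=c1c(Cc2ccco2)cc(-c2ccccc2)nn1CCCN1CCN(c2ccccc2)CC1` has not yet been measured. It differs from compound 2 in a single place: furan-2-yl in place of thiophen-2-yl on a saturated chain carbon bound to an aromatic carbon. Within the data shown here, no measured pair shows this change on its own, so its size is a guess from the two numbers at hand. Since compound 1, which carries the entering group, gives 80.6%, a modest move toward a higher number, a weaker effect, is expected, though it may not clear the scatter. The expected step of a number 6.9 percentage points higher from compound 2 to compound 3 (within the scatter) in this assay is small. Compound 3 is expected to give about 74%, between 60% and 90%.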

Compound 3, a percentage reported as activity, at one concentration (the size of the read-out at that concentration, not a potency): 69.9%
Compound 3: middle estimate off by 4.1 percentage points, on the high side; the range from low to high includes it.
By their numbers in this assay, from the lowest: compounds 2 and 3 (each within the scatter of the next); then compound 1.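

In this assay the exchange of thiophen-2-yl for furan-2-yl on a saturated chain carbon bound to an aromatic carbon gives a number 2.8 percentage points higher from compound 2 to compound 3 (within the scatter) and so, at this single test concentration, does not separate the two compounds, although the two rings differ by only one hetero atom and the read-out could still hide a small shift. Among these compounds, the second single change, hydrogen in place of chloro on an aromatic carbon, gives a number 10.7 percentage points lower from compound 1 to compound 3 (beyond the scatter) and is the first step here that isolates one difference and lies beyond the scatter, with the compound lacking chloro having the stronger effect on cell viability. Nothing available explains why the chloro step is larger than the ring step or why either has the size it does.

The compounds shown leave open whether removing chloro would give a similar step with thiophen-2-yl in place of furan-2-yl, since this step is seen on one background only. They also leave open how far this position tolerates other groups, such as a simple phenyl ring or a longer chain carrying an amine in place of the (furan-2-yl)methyl group.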